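Lengthening the Hexyl Chain: Expected Vero Cell Toxicity

The source may report more compounds than this note shows. Statements on the series, on what has been measured and on what is new or still open speak of the compounds shown alone.

Measured compounds:
compound 1 `CCCCCNc1cnc(C(=O)NCc2ccccc2)cn1` gives > 100000 nM
compound 2 `CCCCCCNc1cncc(C(=O)NCc2ccccc2)n1` gives 100000 nM
compound 3 `O=C(NCc1ccccc1)c1nccnc1Cl` gives "not determined" (no result reported)

In an ADME assay on Vero cells (Chlorocebus sabaeus) for cytotoxicity, read by microscopy, with a stated time of 6 days (on this read-out higher numbers stand for lower toxicity in this test and lower numbers for higher toxicity in this test), compound 2 gives 100000 nM, the only plain number among these compounds. For compound 1 the result is a limit of the assay rather than a number, as noted in the limit of > 100000 nM in this assay, at which 1 of the 3 values shown sits. Compound 3 carries no result at all. Compound 4 `CCCCCCCNc1cncc(C(=O)NCc2ccccc2)n1` differs from compound 2 only by methyl in place of hydrogen on a saturated chain carbon, six bonds along the chain from a nitrogen on an aromatic ring. Within the data shown here, no step between two measured compounds exists to guide the prediction, so the expected change in this assay is none beyond the usual scatter. Compound 4 is therefore expected at 100000 nM, within 50000 nM to 200000 nM, which means an estimated step of no change at the digits printed from compound 2 to compound 4 (within the scatter).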

Compound 4, minimum cytotoxic concentration: > 100000 nM
Compound 4 ended at the assay's limit; the forecaster's own chance of this, stated with the estimate: 40%; the middle value sits exactly at the limit.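

In this assay methyl in place of hydrogen on a saturated chain carbon, six bonds along the chain from a nitrogen on an aromatic ring, gives a number no lower from compound 2 to compound 4 (the limit leaves the size open). This chain position therefore takes one more carbon without a lower number appearing. The value of compound 4 is a limit of the assay, and the results now gather there: the limit of > 100000 nM in this assay, at which 2 of the 4 values shown sit.

As far as these compounds go, how far past that limit compound 4 lies stays open. Also open, from the compounds shown here alone, is whether a longer chain, or an amine or carboxylic acid at the chain end, would bring the number down.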